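The source may report more compounds than this note shows. Statements on the series, on what has been measured and on what is new or still open speak of the compounds shown alone.

Measured so far:
compound 1 `CCCCC(N)c1cc(C(F)(F)F)ccc1N1CCN(C(=O)CCc2ccc(Cl)cc2Cl)CC1`, 190 nM
compound 2 `CC(C)C[C@H](N)c1cc(C(F)(F)F)ccc1N1CCN(C(=O)CCc2c(Cl)cccc2Cl)CC1`, 2600 nM

In an assay on HEK293 cells for displacement of a labelled ligand from Melanocortin receptor 4 (Homo sapiens) (a lower number here means a stronger inhibitor, a higher number a weaker inhibitor), compound 1 gives the lower of the two numbers, and compound 2 gives 2600 nM. The unmeasured compound 3 `CC(C)C[C@H](NC(=O)CN)c1cc(C(F)(F)F)ccc1N1CCN(C(=O)CCc2ccc(Cl)cc2Cl)CC1` differs from compound 1 in one place: 1-(((aminomethyl)carbonyl)amino)-3-methylbutyl in place of 1-aminopentyl on an aromatic carbon. Among the compounds with values here, no step between measured compounds is available to gauge this change, so the expected step is uncertain; the step from compound 1 to compound 3 is expected to be a moderate loss, a 3.2-fold higher number from compound 1 to compound 3 (0.50 log units; beyond the scatter). For compound 3 the estimate in this assay is 600 nM, with a range from 150 nM to 2500 nM.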

Compound 3, inhibition constant: 19 nM
For compound 3 the middle estimate is 32-fold (1.50 log units) above the measured one, outside the stated range (below it).
By their numbers in this assay, from the lowest: compound 3; then compound 1; then compound 2.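

Replacing 1-aminopentyl with 1-(((aminomethyl)carbonyl)amino)-3-methylbutyl gives a 10-fold lower number from compound 1 to compound 3 (1.00 log units; beyond the scatter) in this assay, so this position on the aromatic carbon accepts the larger group and the number falls. The change alters the chain branching, the substitution on the nitrogen and the defined stereocentre at once, so the step belongs to the whole group. Nothing at hand explains the gain.

The compounds shown leave open which part carries the step. An acetyl group on that nitrogen, without the terminal amine, or a dimethylamine in place of that amine would help to separate these parts.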